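Adding a Second Fluoro to Compound 2

This account rests on a few compounds, and the source may have more. Where it says the series, first, only, none or still open, it means among the compounds named here.

Compound 1, `O=C(/C=C/c1ccc(OCc2nc(C3CCN(Cc4ccccc4)CC3)no2)cc1)NO`, gives 71% in an assay on isolated protein for inhibition of protein deacetylase HDAC6 (Homo sapiens), read by fluorescence, with a stated time of 1 h, tested at 100 nM; a lower number here means less inhibition, a higher number more inhibition at the concentration tested (going by the name of the read-out).
Compound 2, `O=C(/C=C/c1ccc(OCc2nc(C3CCN(Cc4ccc(F)cc4)CC3)no2)cc1)NO`, gives 75% in this assay.

Compound 2 has the higher of the two figures, yet the only step shown, a number 4 percentage points higher from compound 1 to compound 2 (within the scatter), is within the scatter, so the two compounds cannot be separated. Compound 3, `O=C(/C=C/c1ccc(OCc2nc(C3CCN(Cc4ccc(F)c(F)c4)CC3)no2)cc1)NO`, is not yet measured. It differs from compound 2 by fluoro in place of hydrogen on an aromatic carbon, the same kind of change that gave a number 4 percentage points higher from compound 1 to compound 2 (within the scatter). That one step is the only measured one bearing on the new compound, and since it was within the scatter, no shift beyond the scatter is expected in this assay for compound 3, in either direction. Compound 3 is therefore estimated at 76%, with a range from 64% to 87%. The expected step is a number 1 percentage points higher from compound 2 to compound 3 (within the scatter).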

Compound 3, a percentage reported as inhibition, at one concentration (the size of the read-out at that concentration, not a potency): 60%
The estimate for compound 3 lay 16 percentage points above the measured number, outside the stated range (below it).
By their numbers in this assay, from the lowest: compound 3; then compounds 1 and 2 (each within the scatter of the next).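

On the 3,4-difluorobenzyl group of compound 3, the added fluoro sits ortho to a fluoro group and gives a number 15 percentage points lower from compound 2 to compound 3 (beyond the scatter) in this assay, so fluoro in place of hydrogen on this aromatic ring is not always a change lost in the scatter. Compound 3 also stands apart from the unsubstituted benzyl compound, with a number 11 percentage points lower from compound 1 to compound 3 (beyond the scatter), so the 3,4-difluorobenzyl group gives a lower number than either the benzyl or the 4-fluorobenzyl group at the concentration tested. Nothing shown gives a reason for this lower number.

The compounds shown leave open whether the lower number follows from the new fluoro alone or from the two fluoro groups together. They also leave open whether a chloro, methoxy or nitrile group on the same aromatic carbon would give a similar number.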